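Swapping a pyridine for a pyrrolidine on the shared core

The source may hold more compounds than are shown below. What is called first, only, known or untested is meant among the compounds shown, and "the series" means these compounds.

Of the compounds shown here, three sharing one core have been measured in a physicochemical assay for solubility, read by LC-MS, in phosphate buffer, measured as thermodynamic solubility, with a stated time of 24 h, at pH 7.4; a higher number here means a more soluble compound, a lower number a less soluble compound. Compound 1 `Cn1cc(-c2cnc3[nH]cc(-c4cccc(N)c4)c3c2)cn1` gives 300000 nM. Compound 3 `Cn1cc(-c2cnc3[nH]cc(-c4cccnc4)c3c2)cn1` gives 97000 nM, the lowest of the two numbers, as a 3.1-fold lower number from compound 1 to compound 3 (0.49 log units; beyond the scatter) shows. For compound 2 `Cn1cc(-c2cnc3[nH]cc(-c4ccc(O)cc4)c3c2)cn1` the assay reports only a limit, < 3000 nM (the limit of < 3000 nM in this assay, at which 1 of the 3 values shown sits). The step of an at least 32-fold higher number from compound 2 to compound 3 (1.50 log units; beyond the scatter) is therefore known only as a bound. Compound 4 `Cn1cc(-c2cnc3[nH]cc(C4CCNC4)c3c2)cn1` differs from compound 3 by pyrrolidin-3-yl in place of pyridin-3-yl on an aromatic carbon. Going by the values given here, no measured step introduces a pyrrolidin-3-yl group, so the two measured steps bear only indirectly: one modest, one large, on this core. Compound 4 is therefore estimated at 250000 nM, within 80000 nM to 800000 nM, an expected step of a 2.6-fold higher number from compound 3 to compound 4 (0.41 log units; beyond the scatter).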

Compound 4, solubility: 1000000 nM
Compound 4: the middle estimate sits 4.0-fold (0.60 log units) below what was measured, and the stated range ends below it.
By their numbers in this assay, from the lowest: compound 3; then compound 1; then compound 4. At a limit, below all of these: compound 2.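

Going by these compounds alone, at this place on the shared core, the earlier compounds all carry an aromatic ring, and the non-aromatic pyrrolidin-3-yl of compound 4 gives the highest number so far in this assay: a 10-fold higher number from compound 3 to compound 4 (1.01 log units; beyond the scatter), and a 3.3-fold higher number from compound 1 to compound 4 (0.52 log units; beyond the scatter). The step of an at least 330-fold higher number from compound 2 to compound 4 (2.52 log units; beyond the scatter) is only a bound, as compound 2 has a limit and not a number: the limit of < 3000 nM in this assay, at which 1 of the 4 values shown sits.

The compounds shown leave open whether the ring nitrogen matters here, which a cyclopentyl group at this place would test. They also leave open whether piperidin-4-yl or an open-chain amine would follow compound 4.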